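Plasma half-life: ethyl in place of cyclopentyl on the amide nitrogen

The source may hold more compounds than are shown below. What is called first, only, known or untested is meant among the compounds shown, and "the series" means these compounds.

The measured compounds in an in vitro ADME assay on a cell-free system (plasma) for pharmacokinetics; a higher number here means that the compound lasts longer, a lower number that the compound disappears faster:
Compound 1, `CCOC(=O)CN(C(=O)/C(C)=C/c1ccc(C(=O)Oc2ccc(C(=N)N)cc2)cc1)C1CCCCC1`, stands at the assay limit of < 0.0834 h, which is a limit and not a number.
Compound 2, `CCOC(=O)C(C(=O)OCC)N(CCCC(=O)O)C(=O)/C(C)=C/c1ccc(C(=O)Oc2ccc(C(=N)N)cc2)cc1`, gives 0.483 h.
Compound 3, `C/C(=C\c1ccc(C(=O)Oc2ccc(C(=N)N)cc2)cc1)C(=O)N(CC(=O)O)C1CCCC1`, gives 0.383 h.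

Among the two numbers actually read out, compound 3 holds the lower one, but its gap to compound 2 lies within the usual scatter, so the two cannot be told apart. Compound 1 sits at the limit (the limit of < 0.0834 h in this assay, at which 1 of the 3 values shown sits).

The next compound, compound 4, `CCN(CC(=O)O)C(=O)/C(C)=C/c1ccc(C(=O)Oc2ccc(C(=N)N)cc2)cc1`, differs from compound 3 in one place: ethyl in place of cyclopentyl on an amide-type nitrogen. For the measured compounds named here, no measured pair covers this change, so there is no step to lean on. Since compounds 2 and 3 sit close together despite different groups on the amide-type nitrogen, the exchange of cyclopentyl for ethyl is expected to move the half-life little, if at all, and any shift is expected to fall within the scatter. Compound 4 is therefore estimated at 0.3 h, with a range from 0.1 h to 0.8 h, meaning an expected step of a 1.3-fold lower number from compound 3 to compound 4 (0.11 log units; within the scatter).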

Compound 4, half-life: 1 h
Estimate against measurement, compound 4: 3.3-fold (0.52 log units) below, outside the stated range (above it).
By their numbers in this assay, from the lowest: compounds 3 and 2 (each within the scatter of the next); then compound 4. At a limit, below all of these: compound 1.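

In this assay, the group on the amide-type nitrogen that also carries the carboxymethyl group proves able to shift the read-out: ethyl in place of cyclopentyl gives a 2.6-fold higher number from compound 3 to compound 4 (0.42 log units; beyond the scatter), a modest step. The earlier compounds shown here could not show this, as no two of them differed in one place alone. Nothing measured in this series accounts for the step.

A single pair leaves open whether the removal of the ring or the shorter carbon group goes with the change, and a methyl, an isopropyl or a cyclopropyl group at the same place would help separate the two. As far as these compounds go, it also remains open whether the same exchange gives a similar step when an ethyl ester stands in place of the carboxylic acid.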